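The compounds below may be only part of what the source reports. "The series", "measured", "known", "first", "only" and "open" are said of these compounds alone.

In a functional assay on A549 cells (Homo sapiens) for antiproliferative activity, read by MTT assay (on this read-out lower numbers stand for stronger inhibition and higher numbers for weaker inhibition), three compounds with a shared core have been measured: compound 1 `COc1cc2c(Oc3ccc(NC(=O)Nc4ccc(OC(F)(F)F)cc4)cc3)ccnc2cc1OCCCCCCC(=O)NO` gives 3130 nM, compound 2 `COc1cc2c(Oc3ccc(NC(=O)Nc4ccc(C(F)(F)F)cc4Cl)cc3)ccnc2cc1OCCCCCCC(=O)NO` gives 970 nM and compound 3 `COc1cc2c(Oc3ccc(NC(=O)Nc4ccccc4F)cc3)ccnc2cc1OCCCCCCC(=O)NO` gives 870 nM. Compound 3 sits level with compound 2, at a 1.1-fold lower number from compound 2 to compound 3 (0.05 log units; within the scatter), and clearly under compound 1, at a 3.6-fold lower number from compound 1 to compound 3 (0.56 log units; beyond the scatter). Compound 4 `COc1cc2c(Oc3ccc(NC(=O)NC4CCCCC4)cc3)ccnc2cc1OCCCCCCC(=O)NO` carries cyclohexyl in place of 2-fluorophenyl on an amide-type nitrogen. The measured steps at this place, such as a 3.2-fold lower number from compound 1 to compound 2 (0.51 log units; beyond the scatter), only exchange one phenyl group for another, and none shows a non-aromatic ring, so they guide the size only loosely. A modest step towards a higher number is expected in this assay, since compound 3 at 870 nM already lies at the low end of the measured range. Compound 4 is estimated at 1800 nM, within an expected range from 600 nM to 5000 nM, the expected step being a 2.1-fold higher number from compound 3 to compound 4 (0.32 log units; beyond the scatter).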

Compound 4, half-maximal inhibitory concentration: 850 nM
Compound 4: the middle estimate sits 2.1-fold (0.33 log units) above what was measured, and the stated range covers the measured number.
By their numbers in this assay, from the lowest: compounds 4, 3 and 2 (each within the scatter of the next); then compound 1.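

Cyclohexyl, with its non-aromatic ring, on this amide-type nitrogen gives a number level with those of two aromatic groups in this assay, namely 2-fluorophenyl (a 1.0-fold lower number from compound 3 to compound 4 (0.01 log units; within the scatter)) and 2-chloro-4-(trifluoromethyl)phenyl (a 1.1-fold lower number from compound 2 to compound 4 (0.06 log units; within the scatter)). Only the 4-(trifluoromethoxy)phenyl compound stands apart (a 3.7-fold lower number from compound 1 to compound 4 (0.57 log units; beyond the scatter)). Among these four compounds, then, an aromatic ring at this place is not required to reach the lowest numbers seen. No measurement shown explains this result. Still open, going by these compounds, is what an amine, a carboxylic acid or a small cyclopropyl ring would give on this nitrogen.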